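Pyrrolidinyl for diisopropylamino on the thiocarbonyl carbon

The source may report more compounds than this note shows. Statements on the series, on what has been measured and on what is new or still open speak of the compounds shown alone.

The series is read in a functional assay on HEp-2 cells (Homo sapiens) for antiproliferative activity, read by MTT assay, with a stated time of 72 h; a lower number here means a stronger inhibitor, a higher number a weaker inhibitor. Compound 1 `COc1ccc2occ(CSC(=S)N(C(C)C)C(C)C)c(=O)c2c1` gives 8900 nM in this assay, and compound 3 `COc1ccc2occ(CSC(=S)N3CCCC3)c(=O)c2c1` gives 3100 nM. The change between them is pyrrolidin-1-yl in place of diisopropylamino on a thiocarbonyl carbon, and the step is a 2.9-fold lower number from compound 1 to compound 3 (0.46 log units; beyond the scatter). Compound 2 `CC(C)N(C(=S)SCc1oc2ccccc2c(=O)c1Cl)C(C)C` gives 20000 nM in this assay, the highest of the three numbers; the difference between the core of compound 2 and the core of compound 1 is not broken down here. Compound 4 `O=c1c(Cl)c(CSC(=S)N2CCCC2)oc2ccccc12` is not yet measured. It differs from compound 2 by pyrrolidin-1-yl in place of diisopropylamino on a thiocarbonyl carbon, the same change as that from compound 1 to compound 3, with the same surroundings at the thiocarbonyl carbon. Within the data shown here, for compound 4 in this assay a step of about a 2.9-fold lower number from compound 2 to compound 4 (0.46 log units; beyond the scatter) is expected, resting on the single measured instance a 2.9-fold lower number from compound 1 to compound 3 (0.46 log units; beyond the scatter); with one pair only, the carry-over to the second core is uncertain. Compound 4 is estimated at 7000 nM, expected between 3000 nM and 16000 nM.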

Compound 4, half-maximal inhibitory concentration: 600 nM
The estimate for compound 4 lay 12-fold (1.07 log units) above the measured number; the measured number lies below the stated range.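

In this assay, pyrrolidin-1-yl in place of diisopropylamino on a thiocarbonyl carbon gives a 33-fold lower number from compound 2 to compound 4 (1.52 log units; beyond the scatter), so the direction of the earlier step carries over to the second core but its size does not: the same change on two cores in this assay, a 2.9-fold lower number (0.46 log units; beyond the scatter) from compound 1 to compound 3 and a 33-fold lower number (1.52 log units; beyond the scatter) from compound 2 to compound 4, 12-fold (1.06 log units) apart, beyond the scatter of two such steps

Within these two pairs the change lowers the number on both cores, but the step measured on one core gave no reliable measure of the step on the other. The pairs do not show which difference between the cores goes with the larger step, as the cores differ in more than one place and no compound shown separates those differences.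

The compounds shown leave open whether the gap between the two steps also appears with other amines on the thiocarbonyl carbon, such as piperidin-1-yl or morpholin-4-yl. As far as these compounds go, it also remains open whether the same gap appears outside this assay.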